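A few compounds are considered here, and "the series" means these few. Any claim that something is new, unique, unknown or untested is made for them only; others in the source may bear on it.

The compounds share one core and differ only in the groups attached to it. In a functional assay on L132 cells (Homo sapiens) for cytotoxicity, read by MTT assay, with a stated time of 72 h (on this read-out lower numbers stand for an effect already at smaller amounts and higher numbers for an effect only at larger amounts of compound), compound 1 `O=C1/C(=C\c2ccc(O)cc2)c2ccccc2N1c1c(Cl)cccc1Cl` gives 30 ug/mL. Compound 2 `COc1ccc(/C=C2\C(=O)N(c3c(Cl)cccc3Cl)c3ccccc32)cc1` reaches only the limit of this assay, > 100 ug/mL, so for compound 2 no number is known. Within the data shown here, the one measured step, methyl in place of hydrogen on an oxygen on an aromatic ring, gives an at least 3.3-fold higher number from compound 1 to compound 2 (0.52 log units; beyond the scatter); this step runs into (the limit of > 100 ug/mL in this assay, at which 1 of the 2 values shown sits), so its true size stays open.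

Compound 3 `O=C1/C(=C\c2cccc(Cl)c2)c2ccccc2N1c1c(Cl)cccc1Cl` is not yet measured. It differs from compound 2 by 3-chlorophenyl in place of 4-methoxyphenyl on a double-bonded chain carbon bound to a double-bonded ring carbon. Among the measured compounds shown here, no measured step concerns such an exchange of the whole aromatic group; the only step recorded concerns a methyl on an oxygen, a group compound 3 no longer carries. The expectation therefore rests on little: the starting point is itself a limit, and the direction of the change is open. Compound 3 is expected to sit near compound 2, and the step is estimated as an at least 1.2-fold lower number from compound 2 to compound 3 (0.09 log units; that floor lies within the scatter). The estimate for compound 3 is 80 ug/mL, within a range from 30 ug/mL to 150 ug/mL.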

Compound 3, concentration for half-maximal effect: 16 ug/mL
The estimate for compound 3 lay 5.0-fold (0.70 log units) above the measured number; the whole stated range lies above it.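

Exchanging the whole aromatic group on a double-bonded chain carbon bound to a double-bonded ring carbon gives, in this assay, an at least 6.2-fold lower number from compound 2 to compound 3 (0.79 log units; beyond the scatter), so this position responds to more than the methyl on the oxygen seen earlier. Going by these compounds, the true size of this step stays open, because one end of it is only a limit: the limit of > 100 ug/mL in this assay, at which 1 of the 3 values shown sits. The second new comparison gives a 1.9-fold lower number from compound 1 to compound 3 (0.27 log units; within the scatter), so 3-chlorophenyl and 4-hydroxyphenyl cannot be told apart here, and a hydroxyl group is not needed at this position for a measurable number in this assay, with compound 2 the one compound shown that stays at the limit.

The compounds shown do not separate the role of the chlorine from that of the aromatic ring, as plain phenyl, with no chlorine, methoxy or hydroxyl on it, is not among them. On these data alone, how an amine or a carboxylic acid on the ring at this position would compare, and whether the same order would hold in other cells, also stays open.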